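This account rests on a few compounds, and the source may have more. Where it says the series, first, only, none or still open, it means among the compounds named here.

Measured so far in a functional assay (Homo sapiens) for inhibition; a lower number here means a stronger inhibitor, a higher number a weaker inhibitor
- Compound 1 `CSc1ccc(CSc2nc(-c3ccc(F)cc3)c(-c3ccncc3)[nH]2)cc1` gives 670 nM
- Compound 2 `CSc1cccc(CSc2nc(-c3ccc(F)cc3)c(-c3ccncc3)[nH]2)c1` gives 550 nM
- Compound 3 `Oc1cccc(CSc2nc(-c3ccc(F)cc3)c(-c3ccncc3)[nH]2)c1` gives 310 nM

Compound 3 stands clear of compound 1 only: a 2.2-fold lower number from compound 1 to compound 3 (0.33 log units; beyond the scatter) is a modest step beyond the scatter. By contrast, a 1.8-fold lower number from compound 2 to compound 3 (0.25 log units; within the scatter) stays within the scatter, so compounds 2 and 3 are not separated.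

The next change leads to compound 4 `CSc1ccc(O)c(CSc2nc(-c3ccc(F)cc3)c(-c3ccncc3)[nH]2)c1` and is 2-hydroxy-5-(methylsulfanyl)phenyl in place of 3-hydroxyphenyl on a saturated chain carbon bound to a sulfur on a saturated chain carbon bound to a sulfur, with 2-hydroxy-5-(methylsulfanyl)phenyl in place of 3-hydroxyphenyl. Among the measured compounds shown here, no measured compound carries hydroxy and methylsulfanyl on one ring, so the evidence is indirect. Exchanging 4-(methylsulfanyl)phenyl for its 3-(methylsulfanyl)phenyl counterpart gave a 1.2-fold lower number from compound 1 to compound 2 (0.09 log units; within the scatter) and stayed within the scatter, as did the exchange of methylsulfanyl for hydroxy noted above. The largest measured step is modest, so no shift beyond the scatter is expected in this assay in either direction. The expected change is a 1.1-fold higher number from compound 3 to compound 4 (0.05 log units; within the scatter) and its direction carries little weight. For compound 4 the estimated value is 350 nM with 120 nM to 1000 nM as the expected range.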

Compound 4, half-maximal inhibitory concentration: 740 nM
The estimate for compound 4 lay 2.1-fold (0.33 log units) below the measured number; low and high end bracket the measured number.
By their numbers in this assay, from the lowest: compounds 3, 2, 1 and 4 (each within the scatter of the next, the first and the last beyond it).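

Working notes on the ring on the saturated chain carbon bound to a sulfur: in this assay, putting 2-hydroxy-5-(methylsulfanyl)phenyl in place of 3-hydroxyphenyl gives a 2.4-fold higher number from compound 3 to compound 4 (0.38 log units; beyond the scatter), a modest step and the first one in the series beyond the scatter towards a weaker inhibitor. Hydroxy and methylsulfanyl on one ring therefore do not add up to the result of compound 3, since hydroxy in place of hydrogen on an aromatic carbon gives a 1.3-fold higher number from compound 2 to compound 4 (0.13 log units; within the scatter) and the exchange for 4-(methylsulfanyl)phenyl gives a 1.1-fold higher number from compound 1 to compound 4 (0.04 log units; within the scatter), so that compound 4 is separated from compound 3 alone and not from the two methylsulfanyl compounds. Nothing available on these compounds accounts for this result.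

The compounds shown leave open whether the step to compound 4 goes with the added methylsulfanyl or with the changed place of the hydroxy, as the two changes arrive together. They also leave open how an amine or a carboxylic acid would read in place of the hydroxy of compound 3.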